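Thiophene in Place of Chlorophenyl: an Expected Value

The source may report more compounds than this note shows. Statements on the series, on what has been measured and on what is new or still open speak of the compounds shown alone.

Going by the values given here, compound 2 `CC1=CC[C@H](C(C)(C)NC(=S)N/N=C/c2ccc(Cl)cc2)CC1` gives 21100 nM in a functional assay on NCI-H460 cells (Homo sapiens) for inhibition, read by sulforhodamine B assay, with a stated time of 48 h (a higher number here means a weaker inhibitor of growth, a lower number a stronger inhibitor of growth), the lower of the two numbers measured so far, while compound 1 `COc1ccc(/C=N/NC(=S)NC(C)(C)[C@H]2CC=C(C)CC2)cc1` gives 47800 nM. Among the compounds with values here, the single measured step, a 2.3-fold lower number from compound 1 to compound 2 (0.36 log units; beyond the scatter), exchanges one substituent on the aromatic ring for another and does not bear on the change now considered. Compound 3 `CC1=CC[C@H](C(C)(C)NC(=S)N/N=C/c2cccs2)CC1` differs from compound 2 by thiophen-2-yl in place of 4-chlorophenyl on a carbon with a double bond to nitrogen. Within the data shown here, with no measured step of this kind to lean on, the expected step of a 1.2-fold higher number from compound 2 to compound 3 (0.07 log units; within the scatter) is small, not beyond the scatter. Compound 3 is therefore estimated at 25000 nM, with a range from 9000 nM to 70000 nM.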

Compound 3, concentration for total growth inhibition: 20800 nM
Beside the measured number, compound 3's estimate is 1.2-fold (0.08 log units) above it, within the range that was stated.
By their numbers in this assay, from the lowest: compounds 3 and 2 (each within the scatter of the next); then compound 1.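

Thiophen-2-yl replaces 4-chlorophenyl on a carbon with a double bond to nitrogen with a 1.0-fold lower number from compound 2 to compound 3 (0.01 log units; within the scatter) and no change beyond the scatter, so a five-membered ring holding sulfur serves here as well as the six-membered ring carrying chlorine. Replacing 4-methoxyphenyl with thiophen-2-yl gives a 2.3-fold lower number from compound 1 to compound 3 (0.36 log units; beyond the scatter) and so the thiophene, like chloro, stands apart from the methoxy compound. From the compounds shown here alone, whether furan-2-yl, pyridin-2-yl or a thiophene bearing an amine would match these numbers stays open. Nothing available explains why the two rings give matching numbers.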